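This account rests on a few compounds, and the source may have more. Where it says the series, first, only, none or still open, it means among the compounds named here.

In a functional assay on MCF7 cells (Homo sapiens) for antiproliferative activity, with a stated time of 48 h (a higher number here means a weaker inhibitor, a lower number a stronger inhibitor), compound 3 `Cc1cc(=O)c2c(O)cc(OC[C@H]3CO3)cc2o1` gives 22900 nM. Compound 1 `Cc1cc(=O)c2c(O)cc(OCC3CO3)cc2o1` has the same atoms and bonds and gives 13600 nM. These two values lie within the usual scatter of each other, at a 1.7-fold higher number from compound 1 to compound 3 (0.23 log units; within the scatter), and what separates the two structures is the fact that one of compounds 1 and 3 is drawn with a defined configuration and the other without, at the place where they differ. Compound 2 `Cc1cc(=O)c2c(OCC3CO3)cc(OCC3CO3)cc2o1` gives 6500 nM, so compound 3 stands with compound 1, clearly above compound 2 on the numbers.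

Compound 4 `Cc1cc(=O)c2c(OC[C@H]3CO3)cc(OC[C@H]3CO3)cc2o1` arises from compound 3 through a single change, ((oxiran-2-yl)methyl in place of hydrogen on an oxygen on an aromatic ring), with (oxiran-2-yl)methyl in place of hydrogen on an oxygen on an aromatic ring. Among the compounds with values here, the closest precedent is the same replacement where the configuration is not drawn, a 2.1-fold lower number from compound 1 to compound 2 (0.32 log units; beyond the scatter), a modest step that lies just beyond the scatter. The step between compound 1 and compound 3 stays within the scatter, so it calls for no separate correction. Within the data shown here, only this one pair supports the expectation, so the size of the step remains uncertain, but a similar modest move towards a lower number is expected, namely a 2.2-fold lower number from compound 3 to compound 4 (0.34 log units; beyond the scatter). For compound 4, the estimated value is 10500 nM, with an expected range from 4500 nM to 25000 nM.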

Compound 4, half-maximal inhibitory concentration: 220000 nM
Estimate against measurement, compound 4: 21-fold (1.32 log units) below; the whole stated range lies below it.
By their numbers in this assay, from the lowest: compound 2; then compounds 1 and 3 (each within the scatter of the next); then compound 4.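

On this oxygen on an aromatic ring, (oxiran-2-yl)methyl in place of hydrogen has no single fixed effect in this assay: with the configuration drawn as R the replacement gives a 9.6-fold higher number from compound 3 to compound 4 (0.98 log units; beyond the scatter), whereas with no configuration drawn it gave a 2.1-fold lower number from compound 1 to compound 2 (0.32 log units; beyond the scatter), a move in the opposite direction. The drawn configuration also counts for far more once this group sits on both oxygens, as the pair with the same atoms and bonds shows a 34-fold higher number from compound 2 to compound 4 (1.53 log units; beyond the scatter), and a single difference goes with that large gap: the fact that one of compounds 2 and 4 is drawn with a defined configuration and the other without, at the place where they differ. Within the data shown here, with only one such group, the comparable step of a 1.7-fold higher number from compound 1 to compound 3 (0.23 log units; within the scatter) stays within the scatter, and the same kind of difference applies there: the fact that one of compounds 1 and 3 is drawn with a defined configuration and the other without, at the place where they differ.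

These values cannot tell what the structures drawn without a configuration contain, so the reason for the reversal remains unknown. Going by these compounds, it also stays open how a longer chain or an amine on this oxygen would behave in place of (oxiran-2-yl)methyl, and whether the S configuration at the ring carbon would bring the number back down.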